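Swapping a Chloro for an Amino on a Fused Core

A few compounds are considered here, and "the series" means these few. Any claim that something is new, unique, unknown or untested is made for them only; others in the source may bear on it.

Among the compounds with values here, compound 1 `ClCc1ccccc1Cn1cnc2c(Cl)nc(Cl)nc21` is one of two compounds measured in a functional assay on SNB-75 cells (Homo sapiens) for cytotoxicity, read by sulforhodamine B assay, with a stated time of 48 h; a lower number here means a stronger inhibitor of growth, a higher number a weaker inhibitor of growth; compound 1 gives 3540 nM. Compound 2 `ClCc1ccc(Cn2cnc3nc(Cl)nc(Cl)c32)cc1` gives 3980 nM in this assay, and the two numbers sit within the usual scatter of each other, so neither can be called stronger. Compound 3 `Nc1nc(Cl)c2ncn(Cc3ccccc3CCl)c2n1` differs from compound 1 in one place: amino in place of chloro on an aromatic carbon. Within the data shown here, no measured pair shows what this swap does, so the expected step from compound 1 to compound 3, a 1.4-fold higher number from compound 1 to compound 3 (0.15 log units; within the scatter), is a small one, possibly toward a slightly higher number, with wide uncertainty. Compound 3 is therefore estimated at 5000 nM, with a range from 1500 nM to 16000 nM.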

Compound 3, concentration for total growth inhibition: 23500 nM
For compound 3 the middle estimate is 4.7-fold (0.67 log units) below the measured one; the whole stated range lies below it.
By their numbers in this assay, from the lowest: compounds 1 and 2 (each within the scatter of the next); then compound 3.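

Amino in place of chloro on an aromatic carbon between two ring nitrogen atoms gives a 6.6-fold higher number from compound 1 to compound 3 (0.82 log units; beyond the scatter) in this assay, so the number at this position does respond to the change. The two earlier compounds, whose values lie within the scatter of each other, could not show this, as they carry chloro here. Nothing available explains the rise in the number.

On these data alone, it remains open whether a methylamino or a methoxy group on this carbon would track amino or chloro. Also open, as far as these compounds go, is whether the same swap on the core of compound 2 would give a step of similar size.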